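From Methoxy to Hydroxy on the Chlorophenyl Ring

The compounds below may be only part of what the source reports. "The series", "measured", "known", "first", "only" and "open" are said of these compounds alone.

Compound 1 `O=C(Nc1cccc(-n2cc(-c3ccncc3)c(-c3ccc(Cl)c(O)c3)n2)c1)Nc1cccc(C(F)(F)F)c1` in a functional assay on IGROV-1 cells (Homo sapiens) for inhibition, read by sulforhodamine B assay, with a stated time of 48 h (a lower number here means a stronger inhibitor of growth, a higher number a weaker inhibitor of growth), gives only a limit, > 32500 nM.
Compound 2 `O=C(Nc1cccc(-n2cc(-c3ccncc3)c(-c3ccc(Cl)c(O)c3)n2)c1)Nc1ccc(Cl)c(Cl)c1` in this assay likewise gives only a limit, > 32500 nM.
Compound 3 `COc1cc(-c2nn(-c3cccc(NC(=O)Nc4ccc(Cl)c(C(F)(F)F)c4)c3)cc2-c2ccncc2)ccc1Cl` in this assay gives 4220 nM.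

Compound 3 is thus the only one of the three with a numerical value in this assay; the other two sit at the limit (the limit of > 32500 nM in this assay, at which 2 of the 3 values shown sit). The step that the two limits leave unreadable from compound 1 to compound 2 cannot be read, since both of its ends are limits.

Compound 4 `O=C(Nc1cccc(-n2cc(-c3ccncc3)c(-c3ccc(Cl)c(O)c3)n2)c1)Nc1ccc(Cl)c(C(F)(F)F)c1` differs from compound 3 by hydrogen in place of methyl on an oxygen on an aromatic ring. Going by the values given here, no measured step changes this group, so no step bears on it directly. What the numbers do show is that compounds 1 and 2, which carry the hydroxy, both sit at the limit (the limit of > 32500 nM in this assay, at which 2 of the 3 values shown sit), while compound 3, which carries the methoxy, gives a number. On that basis the step of a 4.3-fold higher number from compound 3 to compound 4 (0.63 log units; beyond the scatter) is expected to run toward weaker growth inhibition, probably beyond the scatter. Compound 4 is therefore estimated at 18000 nM, with a range from 5000 nM to 60000 nM, and it may well be reported only as a limit.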

Compound 4, concentration for total growth inhibition: 2220 nM
Beside the measured number, compound 4's estimate is 8.1-fold (0.91 log units) above it; the measured number lies below the stated range.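

In this assay, the change from methoxy to hydroxy gives a 1.9-fold lower number from compound 3 to compound 4 (0.28 log units; within the scatter), so this assay does not separate the two groups on this oxygen on an aromatic ring. With the hydroxy kept, the large steps come from changes on an aromatic carbon elsewhere: trifluoromethyl in place of chloro gives an at least 14-fold lower number from compound 2 to compound 4 (1.16 log units; beyond the scatter), and chloro in place of hydrogen gives an at least 14-fold lower number from compound 1 to compound 4 (1.16 log units; beyond the scatter). Carrying the hydroxy therefore does not by itself place a compound at the limit shared by compounds 1 and 2: the limit of > 32500 nM in this assay, at which 2 of the 4 values shown sit.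

As far as these compounds go, whether methoxy and hydroxy also stay level alongside a 3-(trifluoromethyl)phenyl or a 3,4-dichlorophenyl group remains open. Also open, from the compounds shown here alone, is how an amino group or an ethoxy group in the same place would read in this assay.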